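Formyl to acetyl on the shared core

This account rests on a few compounds, and the source may have more. Where it says the series, first, only, none or still open, it means among the compounds named here.

compound 1 `COc1ccc(-c2cn3ccnc3c(-c3ccc4ncn(C5CCCCC5)c4c3)n2)cc1`: 49.9%
compound 2 `O=Cc1ccc(-c2cn3ccnc3c(-c3ccc4ncn(C5CCCCC5)c4c3)n2)cc1`: 27.1%

In a functional assay on SF-268 cells (Homo sapiens) for inhibition, read by sulforhodamine B assay, with a stated time of 48 h, tested at 10 uM (on this read-out higher numbers stand for more inhibition at the one concentration tested (going by the name of the read-out) and lower numbers for less inhibition), compound 2 gives 27.1%, the lower of the two numbers measured; compound 1 gives 49.9%. Compound 3 `CC(=O)c1ccc(-c2cn3ccnc3c(-c3ccc4ncn(C5CCCCC5)c4c3)n2)cc1` differs from compound 2 by methyl in place of hydrogen on a carbonyl carbon. Among the compounds with values here, the only measured step, a number 22.8 percentage points lower from compound 1 to compound 2 (beyond the scatter), concerns a different exchange at the aromatic carbon and does not bear directly on a change at the carbonyl carbon; nothing measured speaks to it. For so small a change a step within the scatter is expected, a number 4.9 percentage points higher from compound 2 to compound 3 (within the scatter). Compound 3 is therefore estimated at 32%, within 15% to 50%.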

Compound 3, a percentage reported as inhibition, at one concentration (the size of the read-out at that concentration, not a potency): 5.01%
For compound 3 the middle estimate is 27 percentage points above the measured one; the measured number lies below the stated range.
By their numbers in this assay, from the lowest: compound 3; then compound 2; then compound 1.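

In this assay the change from formyl to acetyl is not silent: one added methyl on the carbonyl carbon gives a number 22.1 percentage points lower from compound 2 to compound 3 (beyond the scatter) and leaves compound 3 lowest of the three. With a number 44.9 percentage points lower from compound 1 to compound 3 (beyond the scatter) as well, both carbonyl-bearing groups read below methoxy on this aromatic carbon, and the carbonyl carbon proves sensitive to a single added heavy atom. Nothing at hand gives a reason for these steps. Open, going by these compounds, is whether a longer chain such as propanoyl on the carbonyl carbon lowers the number further, or whether an amine or a carboxylic acid in that place raises it again.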